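The source may hold more compounds than are shown below. What is called first, only, known or untested is meant among the compounds shown, and "the series" means these compounds.

Compound 1 `COc1cc(C(c2ccc(O)c(OC)c2)[C@@H](CO)C(C)C)ccc1O`: > 100000 nM (a limit of the assay, not a number)
Compound 2 `COc1cc(C(c2ccc(O)c(OC)c2)[C@H](CF)C(C)C)ccc1O`: 19000 nM

Going by the values given here, in a functional assay on HeLa cells (Homo sapiens) for cytotoxicity, read by WST assay, with a stated time of 48 h (on this read-out lower numbers stand for stronger inhibition and higher numbers for weaker inhibition), compound 2 gives 19000 nM, the only true number so far. The value for compound 1 is only a limit, so compound 2 can be placed against a boundary but not against a second number.

The next compound is compound 3 `COC[C@@H](C(C)C)C(c1ccc(O)c(OC)c1)c1ccc(O)c(OC)c1`. Its structural change is 1-(methoxymethyl)-2-methylpropyl in place of 1-(fluoromethyl)-2-methylpropyl on a saturated chain carbon bound to two aromatic carbons.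

Among the compounds with values here, only one measured step touches this place, an at least 5.2-fold lower number from compound 1 to compound 2 (0.72 log units; beyond the scatter), where fluoromethyl replaced hydroxymethyl. Going by these compounds, the size of that step rests on (the limit of > 100000 nM in this assay, at which 1 of the 2 values shown sits), so its true size remains open. Compound 3 puts an oxygen back into this side chain, and the step of an at least 5.2-fold lower number from compound 1 to compound 2 (0.72 log units; beyond the scatter) gives a weak hint that this could push the number in this assay upward. The expected change is small and probably within the scatter, a 1.5-fold higher number from compound 2 to compound 3 (0.17 log units; within the scatter). For compound 3 the estimated value is 28000 nM, with an expected range from 10000 nM to 80000 nM.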

Compound 3, half-maximal inhibitory concentration: 69000 nM
Estimate against measurement, compound 3: 2.5-fold (0.39 log units) below; the measured number falls inside the stated range.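

In this assay, a second replacement at this position now gives a measured comparison with fluoromethyl: a 3.6-fold higher number from compound 2 to compound 3 (0.56 log units; beyond the scatter). Both side chains carrying oxygen, the hydroxymethyl of compound 1 and the methoxymethyl of compound 3, therefore give higher numbers than the fluoromethyl of compound 2, and none of the compounds shown goes against this. Placing a methyl on the oxygen of compound 1 gives an at least 1.4-fold lower number from compound 1 to compound 3 (0.16 log units; that floor lies within the scatter), and the value of compound 1, > 100000 nM, is a limit and not a number, so the real size of this change stays open: the limit of > 100000 nM in this assay, at which 1 of the 3 values shown sits.

The compounds shown leave open whether the lower number of compound 2 goes with fluorine itself or only with the absence of oxygen from this side chain. A 1-(chloromethyl)-2-methylpropyl group, a plain isobutyl-type hydrocarbon chain or an aminomethyl version at the same place could help to separate these two readings.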